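This account rests on a few compounds, and the source may have more. Where it says the series, first, only, none or still open, it means among the compounds named here.

Measured so far:
- compound 1, `O=C(/C=C/c1ccc([N+](=O)[O-])cc1)c1ccc(O)c(O)c1`: 28000 nM
- compound 2, `Nc1ccc(C(=O)/C=C/c2ccco2)cc1`: 90000 nM

Two related compounds have been tested in a toxicity assay on FHC cells (Homo sapiens) for cytotoxicity, read by resazurin assay, with a stated time of 48 h; a higher number here means that more compound is tolerated, a lower number that less compound is tolerated. Compound 1 gives 28000 nM in this assay, and compound 2 gives 90000 nM. Compound 2 therefore stands highest of the two numbers, its nearest neighbour being compound 1, whose lower number lies beyond the usual scatter, so compound 2 is the better tolerated of the pair.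

The next compound, compound 3, `O=C(/C=C/c1ccco1)c1ccc(NC(=O)c2ccccc2)cc1`, keeps the whole of compound 2 and changes one place: benzoyl in place of hydrogen on a nitrogen on an aromatic ring. Among the measured compounds shown here, no measured pair shows what such a change does here, so the expectation rests on compound 2 alone. A modest downward step is expected in this assay, close to the edge of the scatter, with the number for compound 3 estimated at 50000 nM, in a range from 15000 nM to 150000 nM, which means an expected step of a 1.8-fold lower number from compound 2 to compound 3 (0.26 log units; within the scatter).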

Compound 3, half-maximal cytotoxic concentration: > 100000 nM
Compound 3 was reported as a limit; the forecaster's own chance of this, stated with the estimate: 10%; at least 2.0-fold (0.30 log units) between middle value and limit.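

In this assay compound 3 gives > 100000 nM, which is a limit of the assay and not a number. The nitrogen on the aromatic ring of compound 2 therefore carries a benzoyl group in place of hydrogen with no sign of lost tolerance, and the step reads an at least 1.1-fold higher number from compound 2 to compound 3 (0.04 log units; that floor lies within the scatter). That floor lies within the scatter, so the result shows that this position accepts benzoyl in this assay without proving a gain, and the limit hides how far the true value of compound 3 lies from that of compound 2: the limit of > 100000 nM in this assay, at which 1 of the 3 values shown sits.

The compounds shown leave open whether the same holds for a smaller acetyl group on this nitrogen. From the compounds shown here alone, it also remains open what a carboxylic acid or an amine on the added benzoyl ring would do to the tolerated concentration.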